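This account rests on a few compounds, and the source may have more. Where it says the series, first, only, none or still open, it means among the compounds named here.

For the measured compounds named here, compound 1 `COc1cc(/C(Cl)=C/C=C(\C#N)C(=O)c2c[nH]c3ccccc23)cc(OC)c1OC` is the only member of the series with a number in an ADME assay on Vero cells (Chlorocebus sabaeus) for cytotoxicity, read by sulforhodamine B assay, with a stated time of 48 h; a higher number here means a weaker inhibitor of growth, a lower number a stronger inhibitor of growth: in this assay compound 1 gives 16200 nM. A second analogue, compound 2 `COc1ccc(/C(Cl)=C/C=C(\C#N)C(=O)c2c[nH]c3ccccc23)cc1OC`, carries the entry "not determined" (no result reported) in this assay, so it offers no result for comparison. With a single number in hand, compound 1 stands alone, and no step between measured compounds can be drawn from what is shown.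

Compound 3 `COc1ccc2[nH]cc(C(=O)/C(C#N)=C/C=C(\Cl)c3cc(OC)c(OC)c(OC)c3)c2c1` is still to be measured in this assay. It differs from compound 1 by methoxy in place of hydrogen on an aromatic carbon. Nothing measured bears on this change, so the step is expected to be small, with no direction that rises beyond the scatter, although a slight move toward stronger growth inhibition cannot be excluded. Compound 3 is expected to show a step of a 1.2-fold lower number from compound 1 to compound 3 (0.06 log units; within the scatter). Compound 3 is accordingly estimated at about 14000 nM in this assay, within 5000 nM to 40000 nM.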

Compound 3, concentration for 50% growth inhibition: 9500 nM
The estimate for compound 3 lay 1.5-fold (0.17 log units) above the measured number, and the stated range covers the measured number.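

For the compounds shown here, the first step that can be read in this assay is a 1.7-fold lower number from compound 1 to compound 3 (0.23 log units; within the scatter) for methoxy in place of hydrogen on an aromatic carbon, on a six-membered aromatic ring of carbon only that is part of a fused or bridged system of two rings. At this position, the methoxy group therefore gives compound 3 a growth-inhibition number that cannot be told apart from that of compound 1. Nothing available here offers an explanation for this result.

From the compounds shown here alone, it remains open whether an amine, a carboxylic acid or a longer alkoxy chain at this position would give a step beyond the scatter. Any step involving compound 2 cannot be read, as it has no result in this assay to compare.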